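Notes on the step from compound 2 to compound 4

A few compounds are considered here, and "the series" means these few. Any claim that something is new, unique, unknown or untested is made for them only; others in the source may bear on it.

In an ADME assay on Vero cells (Chlorocebus sabaeus) for cytotoxicity (on this read-out lower numbers stand for higher toxicity in this test and higher numbers for lower toxicity in this test), compound 1 (`CC(=O)c1c(NC(C)C)[nH]c2c(C(F)(F)F)cc(Cl)cc2c1=O`) gives > 25000 nM as a limit and not a number. Compound 2 (`CC(=O)c1c(Nc2ccc(F)cc2F)[nH]c2c(F)cc(F)cc2c1=O`) gives > 25000 nM as a limit too. Compound 3 (`CC(=O)c1c(Nc2ccc(F)cc2F)[nH]c2c(Cl)cc(Cl)c(Cl)c2c1=O`) likewise gives > 25000 nM as a limit. Compound 2 therefore has no number of its own and shares the limit of > 25000 nM in this assay, at which 3 of the 3 values shown sit, with the other two, so it holds no rank within the set.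

Compound 4 (`CC(=O)c1c(Nc2ccc(Cl)cc2)[nH]c2c(F)cc(F)cc2c1=O`) keeps the core of compound 2 and changes one group: 4-chlorophenyl in place of 2,4-difluorophenyl on a nitrogen on an aromatic ring. Among the measured compounds shown here, no step between measured compounds is available, so this change has no measured size to lean on. The expectation in this assay is no step beyond the scatter and no clear direction. It rests on compound 2 with its > 25000 nM as a limit, and a read-out for the new compound at that same limit is the likeliest result. The estimated change is a number no higher from compound 2 to compound 4 (the limit leaves the size open) and no more than that is expected. For compound 4 the estimate is 25000 nM with an expected range from 10000 nM to 50000 nM in this read-out.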

Compound 4, half-maximal cytotoxic concentration: > 25000 nM
Compound 4: a limit, no number (the forecaster's own chance of this, stated with the estimate: 75%); the middle value lies on the limit itself.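

In this assay, compound 2 and compound 4 both read as limits and not numbers, so no step can be read for 4-chlorophenyl in place of 2,4-difluorophenyl. The compounds shown leave open whether any of them differs from another on this read-out, since all share one value: the limit of > 25000 nM in this assay, at which 4 of the 4 values shown sit.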